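Amide-nitrogen substituent and cytotoxicity: compounds 1 to 4

A few compounds are considered here, and "the series" means these few. Any claim that something is new, unique, unknown or untested is made for them only; others in the source may bear on it.

Measured so far in an ADME assay on CEM-SS cells (Homo sapiens) for cytotoxicity, read by XTT assay, with a stated time of 6 days; on this read-out lower numbers stand for higher toxicity in this test and higher numbers for lower toxicity in this test:
- compound 1 `CCCC(=O)OCSc1ccccc1C(=O)NC1(C(N)=O)CCCC1` gives > 100 uM.
- compound 2 `CCCC(=O)OCSc1ccccc1C(=O)NCCCCC(N)=O` gives 51.7 uM.
- compound 3 `CCCC(=O)OCSc1ccccc1C(=O)NCCCNC(C)=O` gives 21.1 uM.

For compound 1 the value in this assay is a limit of the assay and not a number, as the limit of > 100 uM in this assay, at which 1 of the 3 values shown sits, records. Compound 2 and compound 3 replace the 1-carbamoylcyclopentyl on the amide-type nitrogen with open chains, and both give numbers. The step of an at least 1.9-fold lower number from compound 1 to compound 2 (0.28 log units; that floor lies within the scatter); the step of an at least 4.7-fold lower number from compound 1 to compound 3 (0.67 log units; beyond the scatter). Within the pair of chains, a 2.5-fold lower number from compound 2 to compound 3 (0.39 log units; beyond the scatter).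

Compound 4 `CCCC(=O)OCSc1ccccc1C(=O)NC` carries the change (methyl in place of 1-carbamoylcyclopentyl on an amide-type nitrogen). The group that enters has no hydrogen-bond donor and no hydrogen-bond acceptor, whereas the group that leaves has one of each. Both measured steps from compound 1 bear on this change, since each replaces the same group on the same nitrogen, and both run toward lower numbers; but each of them keeps an amide in the entering group, which compound 4 does not. Their bearing is therefore partial. A move toward a lower number than that of compound 1 is expected, with the step estimated as an at least 2.0-fold lower number from compound 1 to compound 4 (0.30 log units; that floor lies within the scatter). For compound 4 the estimated value in this assay is 50 uM, with an expected range from 15 uM to 150 uM.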

Compound 4, half-maximal toxic concentration: 5.7 uM
Compound 4: middle estimate off by 8.8-fold (0.94 log units), on the high side; measured number below the stated range.
By their numbers in this assay, from the lowest: compound 4; then compound 3; then compound 2. At a limit, above all of these: compound 1.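

In this assay the methyl of compound 4 gives the lowest number of the series, and putting it in place of 1-carbamoylcyclopentyl on the amide-type nitrogen gives an at least 17-fold lower number from compound 1 to compound 4 (1.24 log units; beyond the scatter) as a large step at this position. Methyl also sits under both open chains, with a 3.7-fold lower number from compound 3 to compound 4 (0.57 log units; beyond the scatter) and a 9.1-fold lower number from compound 2 to compound 4 (0.96 log units; beyond the scatter) as the steps, so the ring of compound 1 is not the only feature that goes with higher numbers: among these four compounds every substituent that keeps an amide gives a higher number than methyl, and none goes against this. The size of the step from compound 1 is only a floor, because compound 1 stands at a limit of the assay and not at a number: the limit of > 100 uM in this assay, at which 1 of the 4 values shown sits.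

Chain length and the amide in the substituent change together in the compounds shown, so their shares in the drop to compound 4 stay open. A longer plain alkyl chain, or a chain ending in an amine or a carboxylic acid, on the same nitrogen would help to separate the two.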